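The compounds below may be only part of what the source reports. "The series", "measured", "known", "first", "only" and "open" are said of these compounds alone.

Compound 1, `CCNc1nc(-c2ccccc2)nc2c1nnn2Cc1ccccc1Cl`, gives 463 nM in an assay on Cerebral cortex for displacement of a labelled ligand from adenosine receptor A1 (Bos taurus); on this read-out lower numbers stand for stronger inhibition and higher numbers for weaker inhibition.
Compound 2, `CCNc1nc(-c2ccccc2)nc2c1nnn2Cc1ccccc1F`, gives 11 nM in this assay.
Compound 3, `CC(O)CNc1nc(-c2ccccc2)nc2c1nnn2Cc1ccccc1Cl`, gives 32 nM in this assay.

These three compounds share a core and differ in two places. Compound 2 differs from compound 1 by fluoro in place of chloro on an aromatic carbon, and that single change made a 42-fold lower number from compound 1 to compound 2 (1.62 log units; beyond the scatter). Compound 3 differs from compound 1 in the other place, by 1-hydroxyethyl in place of methyl on a saturated chain carbon bound to a nitrogen on an aromatic ring, and that change made a 14-fold lower number from compound 1 to compound 3 (1.16 log units; beyond the scatter). Among the three, compound 3 stands between the others.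

Compound 4, `CC(O)CNc1nc(-c2ccccc2)nc2c1nnn2Cc1ccccc1F`, has not yet been measured in this assay. It differs from compound 3 by fluoro in place of chloro on an aromatic carbon. This is the same change as the one from compound 1 to compound 2, made at the same place in the same words, so it occurs twice among the compounds shown; the two pairs sit on cores that differ from each other as described just above, in the chain bound to the nitrogen.

Because the earlier change made a 42-fold lower number from compound 1 to compound 2 (1.62 log units; beyond the scatter), the step from compound 3 to compound 4 is expected to be of similar size, estimated as a 16-fold lower number from compound 3 to compound 4 (1.20 log units; beyond the scatter), allowing that the second change is often smaller than the first when two favourable changes are combined. On that basis compound 4 is expected to give about 2 nM in this assay, with an estimated range from 0.5 nM to 8 nM.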

Compound 4, inhibition constant: 4.8 nM
Compound 4: the middle estimate sits 2.4-fold (0.38 log units) below what was measured; low and high end bracket the measured number.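

In this assay, putting fluoro in place of chloro on the aromatic ring again lowered the number, with a 6.7-fold lower number from compound 3 to compound 4 (0.82 log units; beyond the scatter), so the direction of this change held on the second core, but its size did not: the same change on two cores in this assay, a 42-fold lower number (1.62 log units; beyond the scatter) from compound 1 to compound 2 and a 6.7-fold lower number (0.82 log units; beyond the scatter) from compound 3 to compound 4, 6.3-fold (0.80 log units) apart, beyond the scatter of two such steps

The other change, 1-hydroxyethyl in place of methyl on the chain bound to the nitrogen, behaved in the same way, giving a 2.3-fold lower number from compound 2 to compound 4 (0.36 log units; beyond the scatter), which is again the same direction but a smaller step than on the chloro compounds: the same change on two cores in this assay, a 14-fold lower number (1.16 log units; beyond the scatter) from compound 1 to compound 3 and a 2.3-fold lower number (0.36 log units; beyond the scatter) from compound 2 to compound 4, 6.3-fold (0.80 log units) apart, beyond the scatter of two such steps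

So in this set each change helps on both cores, yet the two gains do not simply add up, and the size of a step measured on one core is a poor guide to its size on the other; with only one pair of cores, this does not show why the steps shrink or whether the same would happen on any other core.

The compounds shown leave open how a bromo or methoxy group would compare with fluoro at that place on the aromatic ring, and how a longer chain or one ending in an amine would compare on the nitrogen. They also leave open whether either of those groups would show the same shrinking of the step when combined with the other change.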